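A new group on the carbonyl of compound 2

The compounds below may be only part of what the source reports. "The series", "measured", "known", "first", "only" and "open" are said of these compounds alone.

Measured so far in a functional assay on PANC-1 cells (Homo sapiens) for antiproliferative activity, read by MTT assay, with a stated time of 48 h (on this read-out higher numbers stand for weaker inhibition and lower numbers for stronger inhibition), are two compounds.
- Compound 1 `Cc1c(C(=O)OCCCN(C)C)oc2ccc(N(Cc3ccc(Br)cc3)S(=O)(=O)c3ccc(Br)cc3)cc12` gives 24600 nM here
- Compound 2 `Cc1c(C(=O)N2CCCC(C)C2)oc2ccc(N(Cc3ccc(Br)cc3)S(=O)(=O)c3ccc(Br)cc3)cc12` gives 26200 nM here

Compound 2 sits level with compound 1, within the scatter, so the two cannot be ranked. Compound 3 `Cc1ccc(NC(=O)c2oc3ccc(N(Cc4ccc(Br)cc4)S(=O)(=O)c4ccc(Br)cc4)cc3c2C)nc1` keeps the shared core, but (5-methylpyridin-2-yl)amino stands in place of 3-methylpiperidin-1-yl on a carbonyl carbon ((5-methylpyridin-2-yl)amino in place of 3-methylpiperidin-1-yl on a carbonyl carbon). Going by the values given here, one measured step bears on this, at the same carbonyl carbon: a 1.1-fold higher number from compound 1 to compound 2 (0.03 log units; within the scatter), a swap of 3-(dimethylamino)propoxy for 3-methylpiperidin-1-yl that stays within the scatter. Among the compounds with values here, no measured compound carries the incoming group, so the data offer no direction. The expected change in this assay is therefore none beyond the scatter, an estimated 1.2-fold lower number from compound 2 to compound 3 (0.08 log units; within the scatter) only. For compound 3 the estimated value is 22000 nM, with an expected range from 8000 nM to 50000 nM in this read-out.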

Compound 3, half-maximal inhibitory concentration: > 40000 nM
Compound 3 was reported as a limit; the forecaster's own chance of this, stated with the estimate: 15%; middle value at least 1.8-fold (0.25 log units) from the limit.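

In this assay compound 3 is reported only as a limit, > 40000 nM, and not as a number. Read as floors, the data give an at least 1.5-fold higher number from compound 2 to compound 3 (0.18 log units; that floor lies within the scatter) and an at least 1.6-fold higher number from compound 1 to compound 3 (0.21 log units; that floor lies within the scatter), so neither step establishes a real loss of activity, yet neither points to a gain. What is new is that this carbonyl carbon now carries an aromatic ring joined through an amide hydrogen, and this (5-methylpyridin-2-yl)amino group does not bring the number down, whereas the 3-methylpiperidin-1-yl and 3-(dimethylamino)propoxy groups offered no such test.

Going by these compounds, how far compound 3 lies beyond its limit stays unknown, and the ring and the amide hydrogen change together, so their parts cannot be separated. Also open, on these data alone, is how a carboxylic acid or a simple phenylamino group would read on this carbonyl carbon.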